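Pyridin-2-yl in place of benzyl on the triazole

This account rests on a few compounds, and the source may have more. Where it says the series, first, only, none or still open, it means among the compounds named here.

Among the measured compounds shown here, compound 1 `O=C1O/C(=C\Cn2cc(Cc3ccccc3)nn2)C(OCc2ccccc2)=C1OCc1ccccc1` holds the only number in a functional assay on MDA-MB-231 cells (Homo sapiens) for antiproliferative activity, read by MTT assay, with a stated time of 24 h (a lower number here means a stronger inhibitor, a higher number a weaker inhibitor), where compound 1 gives 29200 nM. Compound 2 `CC(C)(C)c1ccc(-c2cn(CCC3(O)NC(=O)C(OCc4ccccc4)=C3OCc3ccccc3)nn2)cc1` reaches only a limit of the assay in this assay, shown as > 100000 nM. Compound 3 `O=C1O/C(=C\Cn2cc(-c3ccccn3)nn2)C(OCc2ccccc2)=C1OCc1ccccc1` awaits measurement; it differs from compound 1 by pyridin-2-yl in place of benzyl on an aromatic carbon. For the measured compounds named here, no measured step of this kind is available, so only a small shift, not beyond the scatter, is expected: a 1.0-fold higher number from compound 1 to compound 3 (0.01 log units; within the scatter). For compound 3 in this assay the estimate is 30000 nM, between 10000 nM and 100000 nM.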

Compound 3, half-maximal inhibitory concentration: > 100000 nM
Compound 3: a limit, no number; the forecaster's own chance of this, stated with the estimate: 25%; at least 3.3-fold (0.52 log units) between middle value and limit.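

Among the compounds shown here, this is the first step read at this place, on an aromatic carbon of a five-membered aromatic ring with 3 nitrogen: in this assay, pyridin-2-yl in place of benzyl gives an at least 3.4-fold higher number from compound 1 to compound 3 (0.53 log units; beyond the scatter). The benzyl group of compound 1 therefore cannot be exchanged for pyridin-2-yl here without a loss of activity. Compound 3 stands at a limit of the assay, so the step has a floor but no measured size: the limit of > 100000 nM in this assay, at which 2 of the 3 values shown sit.

From the compounds shown here alone, whether a phenyl group, pyridin-3-yl or a benzyl group carrying an amine would keep the activity of compound 1 stays open.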